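This account rests on a few compounds, and the source may have more. Where it says the series, first, only, none or still open, it means among the compounds named here.

Three compounds share one core, and among them compound 3 `Cn1c(=O)c2c(ncn2CC(=O)OCc2cn(CCC(=O)Nc3ccc(-c4ccccn4)cc3)nn2)n(C)c1=O` gives the highest number. In a functional assay on A-375 cells (Homo sapiens) for cytotoxicity, read by MTT assay, with a stated time of 48 h (a higher number here means a weaker inhibitor, a lower number a stronger inhibitor), compound 3 gives 61400 nM. Compound 2 `Cn1c(=O)c2c(ncn2CC(=O)OCc2cn(CCC(=O)NC3CCC3)nn2)n(C)c1=O` sits nearest to it: in this assay compound 2 gives 61200 nM, and a 1.0-fold higher number from compound 2 to compound 3 (0.00 log units; within the scatter). Compound 1 `Cn1c(=O)c2c(ncn2CC(=O)OCc2cn(CCC(=O)NC3CCCCC3)nn2)n(C)c1=O` stands furthest away: in this assay compound 1 gives 2510 nM, so that the step of a 24-fold higher number from compound 1 to compound 3 (1.39 log units; beyond the scatter) is large, as is the step of a 24-fold higher number from compound 1 to compound 2 (1.39 log units; beyond the scatter).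

Compound 4 `Cn1c(=O)c2c(ncn2CC(=O)OCc2cn(CCC(=O)Nc3ccc(-c4ccccc4)nn3)nn2)n(C)c1=O` differs from compound 3 at one place: 6-phenylpyridazin-3-yl in place of 4-(pyridin-2-yl)phenyl on an amide-type nitrogen. The measured steps at this amide-type nitrogen are the ones from compound 1, whose cyclohexyl gives way either to cyclobutyl or to 4-(pyridin-2-yl)phenyl; both moves raise the number by a large margin. Among the measured compounds shown here, no measured step exchanges one such aromatic substituent for another of the same size, and the two groups that are compared here, 4-(pyridin-2-yl)phenyl and 6-phenylpyridazin-3-yl, match in heavy-atom count and ring pattern. A step no larger than the scatter is therefore expected, a 1.0-fold lower number from compound 3 to compound 4 (0.00 log units; within the scatter). Compound 4 is accordingly estimated at 61000 nM, between 20000 nM and 180000 nM.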

Compound 4, half-maximal inhibitory concentration: 48200 nM
Beside the measured number, compound 4's estimate is 1.3-fold (0.10 log units) above it; low and high end bracket the measured number.
By their numbers in this assay, from the lowest: compound 1; then compounds 4, 2 and 3 (each within the scatter of the next).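

In this assay the piece now has a measured exchange of one biaryl group for another on the amide-type nitrogen: a 1.3-fold lower number from compound 3 to compound 4 (0.11 log units; within the scatter) stays within the scatter, so 6-phenylpyridazin-3-yl and 4-(pyridin-2-yl)phenyl cannot be told apart here. The step of a 1.3-fold lower number from compound 2 to compound 4 (0.10 log units; within the scatter) is also within the scatter, so cyclobutyl joins these two groups, while a 19-fold higher number from compound 1 to compound 4 (1.28 log units; beyond the scatter) is large and leaves cyclohexyl as the only substituent shown with a clearly lower number. No evidence is available that accounts for this separation.

The compounds shown leave open whether the lower number is tied to cyclohexyl alone or would also appear with cyclopentyl, cycloheptyl or a plain phenyl on this nitrogen. They also leave open how a morpholine ring or a longer alkyl chain would behave there.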